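Swapping Cyclohexyl for 4-(tert-Butyl)phenyl on the Shared Core

A few compounds are considered here, and "the series" means these few. Any claim that something is new, unique, unknown or untested is made for them only; others in the source may bear on it.

Compound 1 `COc1ccc(F)cc1CNCCCNc1ccnc2cc(C3CCCCC3)ccc12` is one of three measured compounds in a physicochemical assay for acid dissociation. In this assay compound 1 gives 9.47. Compound 2 `Fc1ccc(-c2ccc3c(NCCCNCc4ccco4)ccnc3c2)cc1` gives 9.47, and compound 3 `c1coc(CNCCCNc2ccnc3cc(C4CCCCC4)ccc23)c1` gives 9.47, so compound 1 stands level with both at the digits shown, compound 2 being its nearest and compound 3 its furthest neighbour. The two measured steps are no change at the digits printed from compound 1 to compound 3 (within the scatter) and no change at the digits printed from compound 2 to compound 3 (within the scatter).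

Compound 4 `COc1ccc(F)cc1CNCCCNc1ccnc2cc(-c3ccc(C(C)(C)C)cc3)ccc12` differs from compound 1 in a single place: 4-(tert-butyl)phenyl in place of cyclohexyl on an aromatic carbon. The step that bears on this change is the one made at the same aromatic carbon, no change at the digits printed from compound 2 to compound 3 (within the scatter), in which cyclohexyl replaced 4-fluorophenyl without any shift beyond the scatter. On that evidence the step from compound 1 to compound 4 is expected to be no change at the digits printed from compound 1 to compound 4 (within the scatter) in this assay, that is, no shift beyond the scatter in either direction. Compound 4 is therefore estimated at 9.47, expected to lie between 9.17 and 9.77.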

Compound 4, acid dissociation constant: 9.47
Beside the measured number, compound 4's estimate shows no gap at the digits printed; the range from low to high includes it.
By their numbers in this assay, from the lowest: compounds 1, 2, 3 and 4 (each within the scatter of the next).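

The change from cyclohexyl to 4-(tert-butyl)phenyl gives no change at the digits printed from compound 1 to compound 4 (within the scatter) in this assay and adds a second step at this aromatic carbon, this time with the 5-fluoro-2-methoxyphenyl group of compound 1 in place of the furan-2-yl group of compounds 2 and 3. The position has now carried cyclohexyl, 4-fluorophenyl and 4-(tert-butyl)phenyl, the last with 10 heavy atoms against 6 for cyclohexyl, and neither step made there leaves the scatter. Nothing available gives a reason for this result. The compounds shown leave open whether an amine or a carboxylic acid on this aromatic carbon would also leave the number in this assay within the scatter. They also leave open what a longer chain would do in place of the one on the shared core.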